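The source may report more compounds than this note shows. Statements on the series, on what has been measured and on what is new or still open speak of the compounds shown alone.

In a functional assay on K562 cells (Homo sapiens) for inhibition, read by trypan blue exclusion, with a stated time of 72 h (on this read-out higher numbers stand for weaker inhibition and lower numbers for stronger inhibition), compound 1 (`Cn1c(=O)c(S(=O)(=O)c2ccc(F)cc2F)cc2cnc(Nc3ccc4[nH]c(C(=O)O)cc4c3)nc21`) gives 10000 nM and compound 2 (`Cn1c(=O)c(C(=O)Nc2ccc(F)cc2F)cc2cnc(Nc3ccc4[nH]ccc4c3)nc21`) gives 5000 nM while compound 3 (`O=c1[nH]c2nc(Nc3ccc4[nH]ccc4c3)ncc2cc1S(=O)(=O)c1ccc(F)cc1F`) gives 15000 nM on the same read-out. Compound 1 holds the middle place of these three numbers, and its gaps to both others lie within the scatter. Compound 4 (`Cn1c(=O)c(S(=O)(=O)c2ccc(F)cc2F)cc2cnc(Nc3ccccn3)nc21`) differs from compound 1 in one place: pyridin-2-yl in place of 2-carboxy-1H-indol-5-yl on a nitrogen on an aromatic ring. Among the measured compounds shown here, no measured pair tests this exchange. In this assay, for the measured compounds named here, no step beyond the scatter is expected in either direction, the only anchor being compound 1 at 10000 nM and its close neighbours. The expected change is no change at the digits printed from compound 1 to compound 4 (within the scatter) and stays within the scatter. The estimated value for compound 4 is 10000 nM with an expected range from 3000 nM to 30000 nM in this measurement.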

Compound 4, half-maximal inhibitory concentration: 35000 nM
Beside the measured number, compound 4's estimate is 3.5-fold (0.54 log units) below it; the measured number lies above the stated range.
By their numbers in this assay, from the lowest: compounds 2, 1 and 3 (each within the scatter of the next, the first and the last beyond it); then compound 4.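

In this assay, among the compounds shown here, the group on the nitrogen on an aromatic ring gives the first single-place comparison. Pyridin-2-yl in place of 2-carboxy-1H-indol-5-yl gives a 3.5-fold higher number from compound 1 to compound 4 (0.54 log units; beyond the scatter) and so weakens inhibition beyond the scatter, showing that this place affects the read-out. No available evidence gives a cause for this step.

The exchange removes the carboxylic acid and the five-membered ring together, so their separate contributions remain unresolved. As far as these compounds go, it also remains open how a phenyl ring bearing an amine would read at this place.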